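Replacing 3-nitrophenyl with 4-chlorophenyl in a cytotoxicity test

This account rests on a few compounds, and the source may have more. Where it says the series, first, only, none or still open, it means among the compounds named here.

Three related compounds have been tested in an ADME assay on MT4 cells (Homo sapiens) for cytotoxicity, read by MTT assay, with a stated time of 5 days; on this read-out higher numbers stand for lower toxicity in this test and lower numbers for higher toxicity in this test. In this assay, among the compounds with values here, compound 1 (`COc1cc2nc(Nc3ccc(C#N)cc3)nc(Nc3c(C)cc(/C=C/C#N)cc3C)c2cc1OC`) gives 10200 nM, the only plain number so far. Compound 2 (`COc1cc2nc(SCC(=O)Nc3cccc(S(N)(=O)=O)c3)nc(Nc3c(Cl)cc(/C=C/C#N)cc3Cl)c2cc1OC`) gives > 194000 nM, which is a limit and not a number. Compound 3 (`COc1cc2nc([S+]([O-])CC(=O)Nc3cccc([N+](=O)[O-])c3)nc(Nc3c(Cl)cc(/C=C/C#N)cc3Cl)c2cc1OC`) gives >= 83200 nM, which is also a limit, so its position rests on no exact number.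

Compound 4 (`COc1cc2nc([S+]([O-])CC(=O)Nc3ccc(Cl)cc3)nc(Nc3c(Cl)cc(/C=C/C#N)cc3Cl)c2cc1OC`) has 4-chlorophenyl in place of 3-nitrophenyl on an amide-type nitrogen, with the rest of compound 3 unchanged: 4-chlorophenyl in place of 3-nitrophenyl on an amide-type nitrogen. Within the data shown here, no measured pair isolates this change, so the data do not show its effect directly. A moderate step towards lower numbers in this assay is expected, but this is a weak guess, resting only on compound 1 with 10200 nM, which differs from compound 3 in more than one place. Expressed as a step, the estimate is an at least 1.6-fold lower number from compound 3 to compound 4 (0.22 log units; that floor lies within the scatter). For compound 4 the estimated value is 50000 nM, with an expected range from 12000 nM to 190000 nM.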

Compound 4, half-maximal cytotoxic concentration: 14400 nM
For compound 4 the middle estimate is 3.5-fold (0.54 log units) above the measured one; measured number inside the range.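

In this assay, putting 4-chlorophenyl in place of 3-nitrophenyl on the amide-type nitrogen gives an at least 5.7-fold lower number from compound 3 to compound 4 (0.76 log units; beyond the scatter), so with the rest of the molecule unchanged, the group at this position can move the read-out beyond the usual scatter, towards higher toxicity in this test. Compound 4 also gives a plain number, where compound 2 and compound 3 gave only limits. The size of the step is a floor and not an exact figure, because compound 3 has only a limit: the limit of >= 83200 nM in this assay, at which 1 of the 4 values shown sits.

The change swaps the nitro group for chlorine and moves the substituent at the same time, and the compounds shown cannot separate these two effects. A 3-chlorophenyl or a 4-nitrophenyl group would pull them apart, and an unsubstituted phenyl group would show what the ring alone gives in this assay.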